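Amide demethylation on a shared indazole-free carboxamide core

The source may report more compounds than this note shows. Statements on the series, on what has been measured and on what is new or still open speak of the compounds shown alone.

Compound 1, `COc1ccc(NC(=O)c2ccc3[nH]ncc3c2)cc1OC`, in an assay on cells for inhibition of Amine oxidase [flavin-containing] A (Rattus norvegicus) (a lower number here means a stronger inhibitor, a higher number a weaker inhibitor), gives > 10000 nM, which is a limit of the assay and not a number.
Compound 2, `O=C(Nc1ccc(F)c(Cl)c1)c1ccc2cn[nH]c2c1`, in this assay gives > 10000 nM, again a limit.
Compound 3, `COc1ccc(NC(=O)c2ccc3cn[nH]c3c2)cc1Cl`, in this assay gives > 10000 nM, once more a limit.

Compound 3 therefore stands on no number at all in this assay: only a limit is known for it, and the two other values shown are limits as well. The step that the two limits leave unreadable from compound 2 to compound 3 is unreadable, because the limit of > 10000 nM in this assay, at which 3 of the 3 values shown sit, holds both ends of it.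

The next compound, compound 4, `O=C(Nc1ccc(O)c(Cl)c1)c1ccc2cn[nH]c2c1`, differs from compound 3 in one place: hydrogen in place of methyl on an oxygen on an aromatic ring. Within the data shown here, no measured step bears on this change directly. Among the measured compounds shown here, the only neighbouring step, from compound 2 to compound 3, cannot be sized, and all three measured values sit at the same limit, so the data give no direction and no magnitude for the step to be expected in this assay.

Given that every shown value rests at the limit of > 10000 nM in this assay, at which 3 of the 3 values shown sit, compound 4 is expected to remain at the limit as well, with an estimated step that the limit leaves unreadable from compound 3 to compound 4. The estimate for compound 4 in this assay is 15000 nM, within a range from 4000 nM to 60000 nM.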

Compound 4, half-maximal inhibitory concentration: > 10000 nM
Compound 4: only a limit was reported; the forecaster's own chance of this, stated with the estimate: 80%; the middle value does not contradict the limit.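

Compound 4 in this assay gives > 10000 nM as a limit of the assay and not a number. The steps to compound 4 from compound 2 and from compound 3 therefore cannot be read, because both ends of each are limits: the limit of > 10000 nM in this assay, at which 4 of the 4 values shown sit.

The compounds shown leave open how fluoro, methoxy and hydroxy on this ring compare in this assay, and what change to the shared core, if any, would give a measurable value.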